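Fluoro for chloro on the halogenated chalcone

This account rests on a few compounds, and the source may have more. Where it says the series, first, only, none or still open, it means among the compounds named here.

Within the data shown here, the shared core of compound 1 `COc1cc(OC)c(C(=O)/C=C/c2ccc(Cl)cc2)c(OC)c1` carries a chloro group, and in a functional assay on Huh-7 cells (Homo sapiens), read by fluorescence and BrdU incorporation, with a stated time of 48 h, tested at 25 uM (a higher number here means a weaker effect of the compound at the concentration tested, a lower number a stronger effect), compound 1 gives 0.8%, the lowest of the three numbers known. Compound 2 `COc1cccc(/C=C/C(=O)c2c(O)cc(OC)cc2OC)c1` gives 8.5% in this assay, a number within the scatter of compound 1, while compound 3 `COc1cc(O)c(C(=O)/C=C/c2ccccc2SC)c(OC)c1` gives 37%, a number beyond the scatter above compound 1. Compound 4 `COc1cc(OC)c(C(=O)/C=C/c2ccc(F)cc2)c(OC)c1` is not yet measured; it differs from compound 1 by fluoro in place of chloro on an aromatic carbon, on an aromatic carbon of a six-membered aromatic ring of carbon only, para to a large group. Among the measured compounds shown here, no measured pair shows this change, so the expected step is small: from compound 1 to compound 4 a change of a number 4.2 percentage points higher from compound 1 to compound 4 (within the scatter), none beyond the scatter. Compound 4 is therefore estimated at 5%, between 0% and 25%.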

Compound 4, a percentage reported as activity, at one concentration (the size of the read-out at that concentration, not a potency): 1.1%
Beside the measured number, compound 4's estimate is 3.9 percentage points above it, and the stated range covers the measured number.
By their numbers in this assay, from the lowest: compounds 1, 4 and 2 (each within the scatter of the next); then compound 3.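

Fluoro in place of chloro gives the first direct reading at this position: in this assay the exchange of 4-chlorophenyl for 4-fluorophenyl amounts to a number 0.3 percentage points higher from compound 1 to compound 4 (within the scatter) on the shared core. At this place, on this core, the two halogens therefore cannot be told apart by this read-out. Nothing at hand offers an explanation for this result. Going by these compounds, what an amino group or a carboxylic acid would give at the same place remains open, as does whether this exchange reads the same on another core.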